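This account rests on a few compounds, and the source may have more. Where it says the series, first, only, none or still open, it means among the compounds named here.

Compound 1 `Cc1c(COc2cccc(OCC3CCOCC3)c2)[nH]c2ccc(C(=O)O)cc2c1=O`: < 20 mL/min/kg
Compound 2 `Cc1c(COc2cc(OCC3CCOCC3)ccn2)[nH]c2ccccc2c1=O`: 113 mL/min/kg

Both compounds were tested in an in vitro ADME assay on microsomes from liver (Homo sapiens) for metabolic stability, tested at 0.2 uM; a higher number here means faster removal of the compound, a lower number slower removal. Compound 1 stands at the limit of < 20 mL/min/kg in this assay, at which 1 of the 2 values shown sits. From the compounds shown here alone, its < 20 mL/min/kg is a limit and not a number, so the true size of any step from it stays open.

Compound 3 `Cc1c(COc2cccc(OCC3CCOCC3)c2)[nH]c2ccccc2c1=O` is the same structure as compound 1, but with hydrogen in place of carboxy on an aromatic carbon.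

Going by the values given here, no measured pair shows this change on its own, so the nearest guide is compound 2. Compound 2 also has no carboxy and gives 113 mL/min/kg, so a rise well beyond the usual scatter is expected in this assay, meaning faster removal. The expected size of this change is an at least 4.5-fold higher number from compound 1 to compound 3 (0.65 log units; beyond the scatter). For compound 3 the estimated clearance is 90 mL/min/kg, with an expected range of 40 mL/min/kg to 180 mL/min/kg.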

Compound 3, clearance: 214 mL/min/kg
Compound 3: the middle estimate sits 2.4-fold (0.38 log units) below what was measured; measured number outside the range, above it.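

Going by these compounds alone, this is the first direct pair for this change: with the carboxy on this aromatic carbon replaced by hydrogen and the rest of the structure held the same, the clearance reading shows an at least 10-fold higher number from compound 1 to compound 3 (1.02 log units; beyond the scatter) in this assay. This large step, well beyond the usual scatter, ties the difference between slow and fast removal in this pair to this single place on the core. The exact size of the step stays open, because compound 1 carries a limit and not a number: the limit of < 20 mL/min/kg in this assay, at which 1 of the 3 values shown sits.

The compounds shown leave open whether another group on this same aromatic carbon, such as a primary amide, a nitrile or a methyl ester, would also give slow removal. They also leave open how the reading would change with the carboxy on a different carbon of that ring.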